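Small side-chain change on a weakly active series

This account rests on a few compounds, and the source may have more. Where it says the series, first, only, none or still open, it means among the compounds named here.

Measured so far in a functional assay on Ishikawa cells (Homo sapiens) for antiproliferative activity, read by CCK-8 assay, with a stated time of 48 h; a lower number here means a stronger inhibitor, a higher number a weaker inhibitor
compound 1 `C=CC(=O)NCCOc1ccc(Oc2c(-c3ccc(F)cc3)sc3cc(O)ccc23)cc1` gives > 25000 nM (a limit, not a number)
compound 2 `C/C=C/C(=O)N1CC(Oc2ccc(Oc3c(-c4ccc(F)cc4)sc4cc(O)ccc34)cc2)C1` gives 9400 nM
compound 3 `CNC(=O)/C=C/CNCCOc1ccc(Oc2c(-c3ccc(F)cc3)sc3cc(O)ccc23)cc1` gives 15500 nM

Compound 3, at 15500 nM, lies within the scatter of compound 2, at 9400 nM, so these two cannot be told apart.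

Compound 4 `O=C(CCCNCCOc1ccc(Oc2c(-c3ccc(F)cc3)sc3cc(O)ccc23)cc1)N1CCC1` keeps the shared core and alters only the far end of the side chain of compound 3: 2-((azetidin-1-yl)carbonyl)ethyl in place of 2-(methylcarbamoyl)ethenyl on a saturated chain carbon bound to an amine nitrogen. In words, 2-((azetidin-1-yl)carbonyl)ethyl takes the place of 2-(methylcarbamoyl)ethenyl on a saturated chain carbon bound to an amine nitrogen.

For the measured compounds named here, no measured step makes this exact exchange. The nearest evidence comes from larger side-chain exchanges, and these moved the numbers little. One is a 1.6-fold higher number from compound 2 to compound 3 (0.22 log units; within the scatter) and another is an at least 1.6-fold lower number from compound 1 to compound 3 (0.20 log units; that floor lies within the scatter). Going by the values given here, the only step beyond the scatter is an at least 2.6-fold lower number from compound 1 to compound 2 (0.42 log units; beyond the scatter), a modest one that starts from the limit of > 25000 nM in this assay, at which 1 of the 3 values shown sits.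

A smaller edit is therefore expected to stay within the scatter in this assay, with an estimated 1.1-fold lower number from compound 3 to compound 4 (0.04 log units; within the scatter) as the likely outcome. For compound 4 the expected value is 14000 nM, with an estimated range from 6500 nM to 25000 nM.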

Compound 4, half-maximal inhibitory concentration: > 25000 nM
Compound 4: a limit, no number; the forecaster's own chance of this, stated with the estimate: 25%; middle value at least 1.7-fold (0.25 log units) away from the limit.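

In this assay compound 4 gives > 25000 nM, which is a limit and not a number. For the compounds shown here, on a saturated chain carbon bound to an amine nitrogen, placing 2-((azetidin-1-yl)carbonyl)ethyl where 2-(methylcarbamoyl)ethenyl stood gives an at least 1.6-fold higher number from compound 3 to compound 4 (0.20 log units; that floor lies within the scatter), so this change shows no gain and no clear loss, while the wider side-chain exchange gives an at least 2.6-fold higher number from compound 2 to compound 4 (0.42 log units; beyond the scatter), which puts compound 4 clearly behind the only compound in this set with a value beyond the scatter of the limit. As far as these compounds go, the step that joins compound 1 and compound 4 cannot be read, and the true size of the other two steps stays unknown because of the ceiling of the assay: the limit of > 25000 nM in this assay, at which 2 of the 4 values shown sit.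

This single exchange adds a four-membered ring, removes a chain double bond and removes the amide hydrogen all at once, and the compounds shown cannot tell these parts apart. From the compounds shown here alone, a plain methyl amide on the saturated chain, or a dimethylamide on the unsaturated chain, would be the kind of group that could separate them, and how the position responds to a carboxylic acid or a longer chain also remains open.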